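A few compounds are considered here, and "the series" means these few. Any claim that something is new, unique, unknown or untested is made for them only; others in the source may bear on it.

Measured compounds in a functional assay on MCF7 cells (Homo sapiens) for inhibition, read by MTT assay, with a stated time of 72 h; a lower number here means a stronger inhibitor, a higher number a weaker inhibitor:
compound 1 `CN(C(=O)NC(=O)c1ccc(Cl)cc1Cl)c1nc(C(F)(F)F)c(C(=O)N/N=C/c2ccc(C(F)(F)F)cc2)s1` — 8.42 ug/mL
compound 2 `CN(C(=O)NC(=O)c1cccc(C(F)(F)F)c1)c1nc(C(F)(F)F)c(C(=O)N/N=C/c2ccc(C(F)(F)F)cc2)s1` — 6.5 ug/mL

In this assay compound 1 gives 8.42 ug/mL, and compound 2 gives 6.5 ug/mL. Among the measured compounds shown here, the only step between measured compounds, a 1.3-fold lower number from compound 1 to compound 2 (0.11 log units; within the scatter), lies within the scatter, so the two numbers cannot be told apart. That step replaces 2,4-dichlorophenyl with 3-(trifluoromethyl)phenyl on a carbonyl carbon and leaves the shared core of compound 1 untouched.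

Compound 3 `Cc1nc(N(C)C(=O)NC(=O)c2ccc(Cl)cc2Cl)sc1C(=O)N/N=C/c1ccc(C(F)(F)F)cc1` has not yet been measured in this assay. It differs from compound 1 in one place: methyl in place of trifluoromethyl on an aromatic carbon. For the measured compounds named here, no measured step touches the aromatic carbon of the shared core that carries the trifluoromethyl in compound 1; the one available step, a 1.3-fold lower number from compound 1 to compound 2 (0.11 log units; within the scatter), concerns a different part of the molecule and offers no direction for this change. Without a bearing step, the expectation for compound 3 is a number close to that of compound 1, with the direction left open and an allowance wider than the scatter. The estimated step is a 1.0-fold lower number from compound 1 to compound 3 (0.00 log units; within the scatter). Compound 3 is therefore estimated at 8.4 ug/mL, with a range from 3 ug/mL to 24 ug/mL.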

Compound 3, half-maximal inhibitory concentration: 24.5 ug/mL
For compound 3 the middle estimate is 2.9-fold (0.46 log units) below the measured one; the measured number lies above the stated range.
By their numbers in this assay, from the lowest: compounds 2 and 1 (each within the scatter of the next); then compound 3.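

In this assay, among the compounds shown here, the change from trifluoromethyl to methyl gives a 2.9-fold higher number from compound 1 to compound 3 (0.46 log units; beyond the scatter), so this aromatic carbon of the shared core, next to the ring nitrogen, is the first place where a single change separates two compounds beyond the scatter. The earlier step, a 1.3-fold lower number from compound 1 to compound 2 (0.11 log units; within the scatter), lay on the carbonyl side of the molecule and stayed within the scatter, so it gave no sign that either part of the molecule mattered. With the 2,4-dichlorophenyl group held constant, methyl here gives a weaker inhibitor than trifluoromethyl, though the evidence at hand offers no measurement that would explain this difference.

As far as these compounds go, this reading rests on a single pair of compounds, so it remains open whether methyl would cost as much alongside the 3-(trifluoromethyl)phenyl group of compound 2. From the compounds shown here alone, it is also open how this carbon would respond to other substituents, such as a hydrogen, a chlorine atom, an ethyl group or a cyclopropyl ring, and thus whether the number follows any trend across groups.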